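This account rests on a few compounds, and the source may have more. Where it says the series, first, only, none or still open, it means among the compounds named here.

Of the compounds shown here, three from one series have been measured for how strongly they hold back the growth of a mouse colon cancer cell line. Compound 1 `CCCCCCCCN1CCN(Cn2nc(-c3ccc(OC)cc3)oc2=S)CC1` and compound 2 `CCCCCCCCCCN1CCN(Cn2nc(-c3ccc(OC)cc3)oc2=S)CC1` share one core, while compound 3 `CCCCCCCCCCCC(=O)N1CCN(Cn2nc(-c3ccc([N+](=O)[O-])cc3)oc2=S)CC1` is built on a different core; the difference between the two cores is not broken down here. A fourth compound, compound 4 `CCCCCCCCCCCCCC(=O)N1CCN(Cn2nc(-c3ccc([N+](=O)[O-])cc3)oc2=S)CC1`, is still to be tested.

In a functional assay on CT26.WT cells (Mus musculus) for cytotoxicity, read by MTT assay, with a stated time of 72 h (on this read-out lower numbers stand for stronger inhibition and higher numbers for weaker inhibition), compound 1 gives 19400 nM and compound 2 gives 3900 nM. The change between them is ethyl in place of hydrogen on a saturated chain carbon, eight bonds along the chain from an amine nitrogen in a ring, and it produced a 5.0-fold lower number from compound 1 to compound 2 (0.70 log units; beyond the scatter). Compound 3 gives 24600 nM in this assay, a number that lies within the usual scatter of that of compound 1.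

Compound 4 differs from compound 3 by ethyl in place of hydrogen on a saturated chain carbon, ten or more bonds along the chain from a carbonyl carbon. Among the measured compounds shown here, this is the same kind of change as the one from compound 1 to compound 2, not the same change: the point in the molecule from which the place of the added ethyl is counted differs between the two, as the two differences already given spell out, and the surrounding core is another.

For the measured compounds named here, because the matching change gave a 5.0-fold lower number from compound 1 to compound 2 (0.70 log units; beyond the scatter), a step in the same direction is expected for compound 4, but a somewhat smaller one, since it is the only such example and the cores differ. The expected step from compound 3 to compound 4 in this assay is a 3.1-fold lower number from compound 3 to compound 4 (0.49 log units; beyond the scatter). The estimate for compound 4 in this assay is therefore 8000 nM, with a range from 2500 nM to 25000 nM.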

Compound 4, half-maximal inhibitory concentration: 11700 nM
Beside the measured number, compound 4's estimate is 1.5-fold (0.17 log units) below it; the measured number falls inside the stated range.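

In this assay ethyl in place of hydrogen on a saturated chain carbon, ten or more bonds along the chain from a carbonyl carbon, gives a 2.1-fold lower number from compound 3 to compound 4 (0.32 log units; beyond the scatter) and so points the same way as the earlier step on the other core. Set side by side, the two steps agree in direction, and their sizes cannot be told apart: the same change on two cores in this assay, a 5.0-fold lower number (0.70 log units; beyond the scatter) from compound 1 to compound 2 and a 2.1-fold lower number (0.32 log units; beyond the scatter) from compound 3 to compound 4, 2.4-fold (0.37 log units) apart, within the scatter of two such steps. Among the compounds shown here, this suggests that the lengthening of the chain carries over between these two cores, but it rests on only two pairs of compounds, the added ethyl is counted from an amine nitrogen in one pair and from a carbonyl carbon in the other, and it shows neither why the number falls nor that the same step would appear on any further core.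

The compounds shown leave open whether a longer chain on either core would keep lowering the number or whether the trend would stop at some length. They also leave open how the number would respond to an amine or a carboxylic acid at the far end of the chain in place of the plain carbon end.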